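The source may report more compounds than this note shows. Statements on the series, on what has been measured and on what is new or still open speak of the compounds shown alone.

Measured so far:
compound 1, `CCC/C=C/c1c(C(C)C)nc(C(C)C)c(CO)c1-c1ccc(Cl)c(Cl)c1`, 39%
compound 2, `CCCCCc1c(C(C)C)nc(C(C)C)c(CO)c1-c1ccccc1OC`, 27%

Both compounds share one core and were tested in an assay on CHO cells for inhibition of Glucagon receptor (Homo sapiens), tested at 20 uM; on this read-out higher numbers stand for more inhibition at the one concentration tested (going by the name of the read-out) and lower numbers for less inhibition. Compound 1 gives 39%, and compound 2 gives 27%. Of these two numbers, compound 2 stands lowest, and its gap to compound 1 is beyond the usual scatter of this kind of measurement. Compound 1 and compound 2 differ in more than one place, so no single change can be read from that pair.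

Compound 3, `CCCCCc1c(C(C)C)nc(C(C)C)c(CO)c1-c1ccc(CC)cc1`, has not yet been measured. It differs from compound 2 in one place: 4-ethylphenyl in place of 2-methoxyphenyl on an aromatic carbon. The group that changes sits on the aromatic carbon of the six-membered ring with one nitrogen, opposite the ring nitrogen, with the hydroxymethyl and pentyl groups ortho to it.

For the measured compounds named here, no measured pair shows this particular exchange, so there is no step to lean on. Compound 3 is therefore expected to stay close to compound 2, with an expected step of a number 5 percentage points higher from compound 2 to compound 3 (within the scatter) that may well fall within the scatter. The estimate for compound 3 in this assay is 32%, within a range from 12% to 55%.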

Compound 3, a percentage reported as inhibition, at one concentration (the size of the read-out at that concentration, not a potency): 42%
Compound 3: the middle estimate sits 10 percentage points below what was measured; measured number inside the range.
By their numbers in this assay, from the lowest: compound 2; then compounds 1 and 3 (each within the scatter of the next).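

For the compounds shown here, exchanging the 2-methoxyphenyl for 4-ethylphenyl on the aromatic carbon opposite the ring nitrogen gives the first comparison in one place in this assay, a number 15 percentage points higher from compound 2 to compound 3 (beyond the scatter), showing that this position responds to which substituted phenyl it carries. The two groups have the same 8 heavy atoms and the same carbon ring, and the leaving group has 1 hydrogen-bond acceptor where the entering group has 0, yet the exchange replaces the substituent and moves it around the phenyl ring at once, so this single step cannot separate the two changes. Nothing measured here gives a reason for the step.

Open, going by these compounds, is whether the gain follows the ethyl group or its place on the phenyl ring, a question that 4-methoxyphenyl and 2-ethylphenyl at this same carbon would address. Also open, on these data alone, is whether the inhibition in this assay is higher, lower or level with other groups on the phenyl ring, such as an amine, a carboxylic acid or a chain longer than ethyl.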